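Adding a methylsulfanyl arm to a thiol on a citrate-like core

This account rests on a few compounds, and the source may have more. Where it says the series, first, only, none or still open, it means among the compounds named here.

Measured so far:
- compound 1 `CS[C@H](C(=O)O)[C@@](O)(CC(=O)O)C(=O)O`: 34000 nM
- compound 2 `O=C(O)CC(S)(CC(=O)O)C(=O)O`: 295000 nM

Among the measured compounds shown here, in an assay on isolated protein with ATP-citrate synthase (Rattus norvegicus) as the target (a higher number here means a weaker inhibitor, a lower number a stronger inhibitor), compound 2 gives 295000 nM, the higher of the two numbers known, while compound 1 gives 34000 nM, a clearly lower number that lies beyond the usual scatter. Compound 1 and compound 2 differ in more than one place, so no single change can be read from that gap.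

Compound 3 `CSSC(CC(=O)O)(CC(=O)O)C(=O)O` keeps the core of compound 2 and changes one thing: methylsulfanyl in place of hydrogen on a sulfur. The new group is a methylsulfanyl, the same kind of arm that compound 1 carries, though there it sits on a carbon rather than on a sulfur.

Compound 3 is expected to move somewhat toward compound 1, a step of a 3.0-fold lower number from compound 2 to compound 3 (0.47 log units; beyond the scatter) in this assay, because compound 1 with its methylsulfanyl arm gives 34000 nM. Compound 3 is therefore estimated at 100000 nM, with a range from 30000 nM to 400000 nM.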

Compound 3, inhibition constant: 480000 nM
Compound 3: middle estimate off by 4.8-fold (0.68 log units), on the low side, outside the stated range (above it).
By their numbers in this assay, from the lowest: compound 1; then compounds 2 and 3 (each within the scatter of the next).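

In this assay, methylsulfanyl in place of hydrogen on a sulfur gives a 1.6-fold higher number from compound 2 to compound 3 (0.21 log units; within the scatter), so this change leaves the two compounds indistinguishable. The hydrogen on this sulfur, whose other neighbour is a saturated chain carbon, can therefore be replaced by this two-heavy-atom group with no difference beyond the usual scatter of the assay. Nothing available explains why the reading stays within that scatter.

The compounds shown leave open whether a different group on this sulfur, such as a longer chain like ethylsulfanyl or a carboxylic acid-bearing chain, would give a clearly different number. They also leave open which of the several differences between compound 1 and compound 2 goes with the lower number of compound 1.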